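Swapping a Saturated Ring for a Fused One

This account rests on a few compounds, and the source may have more. Where it says the series, first, only, none or still open, it means among the compounds named here.

Measured so far:
compound 1, `CNC(=O)c1cc(Oc2ccc(Nc3nccc(N4CCCCC4)n3)cc2)ccn1`: 52.3%
compound 2, `c1cc(N2CCCCC2)nc(Nc2ccc(Oc3ncnc4ccsc34)cc2)n1`: 45.7%

In a functional assay on MDA-MB-231 cells (Homo sapiens) for inhibition, read by MTT assay, with a stated time of 72 h, tested at 20 uM (on this read-out lower numbers stand for less inhibition and higher numbers for more inhibition at the one concentration tested (going by the name of the read-out)), compound 1 gives 52.3% and compound 2 gives 45.7%. These two numbers lie within the usual scatter of each other, so neither compound stands apart from the other on this read-out. Among the compounds with values here, the single step measured so far, a number 6.6 percentage points lower from compound 1 to compound 2 (within the scatter), alters the group on the ether oxygen and leaves the number inside the scatter.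

Compound 3, `CNC(=O)c1cc(Oc2ccc(Nc3nccc(N4CCc5ccccc5C4)n3)cc2)ccn1`, keeps the whole of compound 1 except at one place: 1,2,3,4-tetrahydroisoquinolin-2-yl in place of piperidin-1-yl on an aromatic carbon. Within the data shown here, no measured step touches this place. Among the measured compounds shown here, the one step that is known bears on another part of the molecule and so gives no guide to how large the new change will be or in which direction it will act. The only safe starting point is the number of compound 1 itself, with a range wide enough to allow a move either way.

Compound 3 is therefore expected to give about 50%, somewhere between 25% and 75%. The step of a number 2.3 percentage points lower from compound 1 to compound 3 (within the scatter) is estimated to stay near zero, with the uncertainty spread evenly on both sides.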

Compound 3, a percentage reported as inhibition, at one concentration (the size of the read-out at that concentration, not a potency): 41.2%
Beside the measured number, compound 3's estimate is 8.8 percentage points above it; the measured number falls inside the stated range.
By their numbers in this assay, from the lowest: compounds 3, 2 and 1 (each within the scatter of the next, the first and the last beyond it).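

In this assay, replacing piperidin-1-yl with 1,2,3,4-tetrahydroisoquinolin-2-yl gives a number 11.1 percentage points lower from compound 1 to compound 3 (beyond the scatter). This shows that the group on this aromatic carbon of the six-membered aromatic ring with 2 nitrogen can shift the read-out, which the earlier step at the ether oxygen could not show because it stayed within the scatter and concerned another part of the molecule. The two groups have the same counts of hydrogen-bond donors and acceptors and neither carries a net charge, so the listed difference is the added six-membered aromatic ring of carbon only, although no measurement here explains why the number falls.

This single modest step cannot show whether the added ring or simply the larger group matters, and it gives no trend across this position. A smaller ring such as pyrrolidine, a morpholine with its ring oxygen, or an open-chain dimethylamino group at the same place would begin to answer that, as would the same swap made on compound 2.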